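Swapping fluoro for hydrogen on compound 2

The source may report more compounds than this note shows. Statements on the series, on what has been measured and on what is new or still open speak of the compounds shown alone.

Values in a functional assay on DU-145 cells (Homo sapiens) for cytotoxicity, read by MTT assay, with a stated time of 48 h (on this read-out lower numbers stand for stronger inhibition and higher numbers for weaker inhibition), are:
Compound 1 `COc1cc(-c2cc(COCc3cn(Cc4cc(C)cnc4Cl)nn3)on2)cc(OC)c1OC` gives 39800 nM here
Compound 2 `COc1cc(COCc2cn(Cc3cc(-c4ccc(F)cc4)cnc3Cl)nn2)cc(OC)c1OC` gives 38800 nM here
Compound 3 `COc1cc(C2CC(COCc3cn(Cc4cc(-c5ccc(F)cc5)cnc4Cl)nn3)ON2C=O)cc(OC)c1OC` gives 32800 nM here

Compound 2 at 38800 nM lies within the usual scatter of both compound 1 and compound 3, so no order can be read among the three. Compound 4 `COc1cc(COCc2cn(Cc3cc(-c4ccccc4)cnc3Cl)nn2)cc(OC)c1OC` differs from compound 2 in one place, counted as hydrogen in place of fluoro on an aromatic carbon and described as hydrogen in place of fluoro on an aromatic carbon, which turns 4-fluorophenyl to phenyl. For the measured compounds named here, no measured pair isolates a single change, so the data give no direct size for this step. Compound 1 carries no 4-fluorophenyl group, yet compound 1 at 39800 nM stays within the scatter of compound 2. In this assay the expectation is therefore no shift beyond the scatter in either direction. The expected 1.0-fold higher number from compound 2 to compound 4 (0.01 log units; within the scatter) would be small. For compound 4 the estimate is 40000 nM with an expected range from 22000 nM to 75000 nM in this read-out.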

Compound 4, half-maximal inhibitory concentration: 45500 nM
Beside the measured number, compound 4's estimate is 1.1-fold (0.06 log units) below it, and the stated range covers the measured number.
By their numbers in this assay, from the lowest: compounds 3, 2, 1 and 4 (each within the scatter of the next).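

For the compounds shown here, compound 4 gives the first direct comparison at this position: in this assay, replacing the fluoro with hydrogen on the six-membered aromatic ring gives a 1.2-fold higher number from compound 2 to compound 4 (0.07 log units; within the scatter), a step within the usual scatter of repeated measurements. On this read-out, then, fluoro and hydrogen at this place cannot be told apart, and the fluorine atom shows no measurable contribution in this one pair. No other measurement shown here bears on this result.

The compounds shown leave open whether a different group at this place, such as an amine, a hydroxyl or a carboxylic acid, would move the number beyond the scatter. They also leave open whether the same swap would give a similar result on the core of compound 3, which carries the same 4-fluorophenyl group.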